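Dimethylamino to diethylamino on the benzylic carbon

This account rests on a few compounds, and the source may have more. Where it says the series, first, only, none or still open, it means among the compounds named here.

Of the compounds shown here, two built on the same core have been measured in an assay on isolated protein for binding affinity to 5-hydroxytryptamine receptor 5A (Homo sapiens); a higher number here means a weaker inhibitor, a lower number a stronger inhibitor. Compound 1 `COc1ccccc1-c1cc(C2CCN(C)C2)ccc1Cl` gives 1000 nM. Compound 2 `COc1ccccc1-c1cc(CN(C)C)ccc1Cl` gives 220 nM, the lowest of the two numbers; the step of a 4.5-fold lower number from compound 1 to compound 2 (0.66 log units; beyond the scatter) separates them, and it comes from replacing 1-methylpyrrolidin-3-yl on an aromatic carbon by (dimethylamino)methyl.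

Compound 3 `CCN(CC)Cc1ccc(Cl)c(-c2ccccc2OC)c1` has not yet been measured. It differs from compound 2 in one place: diethylamino in place of dimethylamino on a saturated chain carbon bound to an aromatic carbon. Among the measured compounds shown here, no measured step bears directly on this change; the only step in hand, a 4.5-fold lower number from compound 1 to compound 2 (0.66 log units; beyond the scatter), concerns a different alteration, a ring replaced by a chain, and says nothing about lengthening the alkyl groups on the nitrogen. With no guiding comparison, the expectation is for a change in this assay that stays within the usual scatter, with only a slight lean toward a higher number: the estimated step is a 1.4-fold higher number from compound 2 to compound 3 (0.13 log units; within the scatter).

For compound 3 in this assay the estimated value is 300 nM, expected to fall between 100 nM and 900 nM.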

Compound 3, inhibition constant: 230 nM
Compound 3: middle estimate off by 1.3-fold (0.12 log units), on the high side; measured number inside the range.
By their numbers in this assay, from the lowest: compounds 2 and 3 (each within the scatter of the next); then compound 1.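

In this assay, diethylamino and dimethylamino on a saturated chain carbon bound to an aromatic carbon stand within the scatter of each other, with a 1.0-fold higher number from compound 2 to compound 3 (0.02 log units; within the scatter), even though the entering group has 5 heavy atoms and the leaving group 3. The replacement of 1-methylpyrrolidin-3-yl can now be read with two different chains, a 4.5-fold lower number from compound 1 to compound 2 (0.66 log units; beyond the scatter) and a 4.3-fold lower number from compound 1 to compound 3 (0.64 log units; beyond the scatter), and each step lies beyond the scatter, so in these compounds the advantage of the open chain over the ring holds with either pair of alkyl groups on the nitrogen. Nothing in hand accounts for the two amines reading alike.

Going by these compounds, how far this tolerance extends remains open: dipropylamino, or a cyclic amine such as piperidin-1-yl or morpholin-4-yl, on the same carbon could show whether larger groups on the nitrogen read the same, and a primary amine would test the opposite direction. Also open, on these data alone, is what the chloro and methoxy groups of the shared core contribute; all three compounds carry both.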